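The source may report more compounds than this note shows. Statements on the series, on what has been measured and on what is new or still open speak of the compounds shown alone.

Working notes on the series. Compound 1 `CCSc1sc(-n2nc(C)c(Cc3ccccc3[N+](=O)[O-])c2C(=O)O)nc1-c1ccc(Cl)c(Cl)c1` gives 59000 nM in a functional assay on BJAB cells (Homo sapiens) for antiproliferative activity, with a stated time of 4 days; a lower number here means that less compound is needed, a higher number that more compound is needed for the effect. Compound 2 `Cc1c(-c2cc(Cl)cc(Cl)c2)c(C(=O)O)nn1-c1nc(-c2cnn(C)c2)c(SC(C)C)s1` is reported as "not active" (no number reported) in this assay, with no number given for it. Compound 3 `Cc1nn(-c2nc(-c3ccc(Cl)c(Cl)c3)c(SC(C)C)s2)c(C(=O)O)c1-c1cccc(C(F)(F)F)c1` gives 22000 nM in this assay, the lower of the two numbers available; the number for compound 1 stands higher, and that gap lies beyond the usual scatter. Within the data shown here, no two measured compounds differ in only one place, so no single-point step is known from the measurements so far.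

Compound 4 `Cc1nn(-c2nc(-c3ccc(Cl)c(Cl)c3)c(SC(C)C)s2)c(C(=O)O)c1-c1ccc(C(F)(F)F)cc1` differs from compound 3 by 4-(trifluoromethyl)phenyl in place of 3-(trifluoromethyl)phenyl on an aromatic carbon, the change sitting on an aromatic carbon of a five-membered aromatic ring with 2 nitrogen. Among the measured compounds shown here, with no comparable step among the measured compounds, the size of this step in this assay cannot be read from the data; the expectation is for no change beyond the scatter, in either direction. Compound 4 is therefore expected to give 25000 nM in this assay, within 10000 nM to 60000 nM. The estimated step in this assay is thus a 1.1-fold higher number from compound 3 to compound 4 (0.06 log units; within the scatter).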

Compound 4, half-maximal effective concentration: 3500 nM
Estimate against measurement, compound 4: 7.1-fold (0.85 log units) above; measured number below the stated range.
By their numbers in this assay, from the lowest: compound 4; then compound 3; then compound 1.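

In this assay, among these compounds, 4-(trifluoromethyl)phenyl in place of 3-(trifluoromethyl)phenyl on the aromatic carbon gives a 6.3-fold lower number from compound 3 to compound 4 (0.80 log units; beyond the scatter), the first single-place step. The two groups have the same heavy atoms and the same counts of donors and acceptors, so this position responds to how the group is joined and not only to which atoms it holds. Nothing at hand accounts for the size of this step.

As far as these compounds go, it remains open whether the lower number belongs to the trifluoromethyl group itself or would persist with a nitrile or an amine in its place on the phenyl ring. The data also leave open whether a phenyl ring is needed at this position, or whether an unsubstituted phenyl would give a comparable number.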